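The source may hold more compounds than are shown below. What is called first, only, known or untested is meant among the compounds shown, and "the series" means these compounds.

For the measured compounds named here, in a functional assay on A549 cells (Homo sapiens) for inhibition, read by MTT assay, with a stated time of 72 h (a lower number here means a stronger inhibitor, a higher number a weaker inhibitor), compound 1 `CC(=O)Oc1cc(C(=O)C2=C(O)[C@]3(CC=C(C)C)C[C@@H](C/C=C(\C)CCC=C(C)C)[C@](C)(CCC=C(C)C)[C@](CC=C(C)C)(C2=O)C3=O)ccc1O` gives 7660 nM and holds the lower of the two numbers so far, while compound 2 `CC(=O)Oc1ccc(C(=O)C2=C(O)[C@]3(CC=C(C)C)C[C@@H](C/C=C(\C)CCC=C(C)C)[C@](C)(CCC=C(C)C)[C@](CC=C(C)C)(C2=O)C3=O)cc1OC(C)=O` gives 16600 nM as the only other measured value. Compound 3 `CC(C)=CCC/C(C)=C/C[C@@H]1C[C@]2(CC=C(C)C)C(=O)[C@@](CC=C(C)C)(C(=O)C(C(=O)c3ccc(O)c(OC(=O)CCCC[C@@H]4SCC5NC(=O)NC54)c3)=C2O)[C@@]1(C)CCC=C(C)C` has not been measured yet. Its difference from compound 1 is this: a group of 12 heavy atoms (8 carbon, 2 nitrogen, 1 oxygen, 1 sulfur; one five-membered non-aromatic ring with 1 hetero atom, one five-membered non-aromatic ring with 2 hetero atoms) in place of a hydrogen atom, on a saturated chain carbon bound to a carbonyl carbon. Going by the values given here, no measured compound carries this new group, so the evidence is thin. Just one measured step bears on it, and only loosely: acetyl in place of hydrogen on an oxygen on an aromatic ring gave a 2.2-fold higher number from compound 1 to compound 2 (0.34 log units; beyond the scatter), a modest rise. Going by that single step, a modest move towards a higher number is expected in this assay rather than a large one. The estimated step is a 2.0-fold higher number from compound 1 to compound 3 (0.29 log units; within the scatter), with wide uncertainty. Compound 3 is estimated at 15000 nM, with an expected range from 5000 nM to 45000 nM.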

Compound 3, half-maximal inhibitory concentration: 11300 nM
Compound 3: middle estimate off by 1.3-fold (0.12 log units), on the high side; the range from low to high includes it.
By their numbers in this assay, from the lowest: compounds 1, 3 and 2 (each within the scatter of the next, the first and the last beyond it).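

In this assay, the new group gives a 1.5-fold higher number from compound 1 to compound 3 (0.17 log units; within the scatter), so the number for compound 3 cannot be told apart from that of compound 1. This group of 12 heavy atoms, with its two five-membered non-aromatic rings, stands in place of a hydrogen atom on a saturated chain carbon bound to a carbonyl carbon. For the compounds shown here, the earlier step involved only an acetyl group, so compound 3 is the first sign that a far larger group can be carried with no shift beyond the scatter. No measurement shown gives a reason for this.

From the compounds shown here alone, whether the two rings matter remains open, as a plain saturated chain at the same place could read alike or differently. Going by these compounds, how a carboxylic acid or an amine there would read in this assay is also open.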